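The source may report more compounds than this note shows. Statements on the series, on what has been measured and on what is new or still open speak of the compounds shown alone.

Measured in a functional assay on HCT-8 cells (Homo sapiens) for antiproliferative activity, read by MTT assay, with a stated time of 48 h; a lower number here means a stronger inhibitor, a higher number a weaker inhibitor:
- compound 1 `COc1ccc(C(=O)c2ccc(OC)c3c2C=CC(C)(C)O3)c(NC(=O)CO)c1`: 630 nM
- compound 2 `CCNCC(=O)Nc1cc(OC)ccc1C(=O)c1ccc(OC)c2c1OC(C)(C)C=C2`: 3690 nM

Of these two, compound 1 has the lower number and is the stronger inhibitor in this assay. Compound 2 stands above it, by a gap beyond the usual scatter.

The next compound to be tested is compound 3 `COc1ccc(C(=O)c2ccc(OC)c3c2C=CC(C)(C)O3)c(NC(=O)CN(C)C)c1`, which carries dimethylamino in place of the hydroxy of compound 1, on a saturated chain carbon bound to a carbonyl carbon (dimethylamino in place of hydroxy on a saturated chain carbon bound to a carbonyl carbon). Among the compounds with values here, no measured pair isolates this change, so any forecast remains loose. Within the data shown here, the only guide is compound 2, whose chain also carries an amino group and which gives 3690 nM. This suggests a modest loss of potency rather than a gain. The expected change is a 2.4-fold higher number from compound 1 to compound 3 (0.38 log units; beyond the scatter). For compound 3, the estimated value is 1500 nM, with an expected range from 350 nM to 6000 nM.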

Compound 3, half-maximal inhibitory concentration: 5660 nM
Compound 3: middle estimate off by 3.8-fold (0.58 log units), on the low side; measured number inside the range.
By their numbers in this assay, from the lowest: compound 1; then compounds 2 and 3 (each within the scatter of the next).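

In this assay, within the data shown here, the step of a 9.0-fold higher number from compound 1 to compound 3 (0.95 log units; beyond the scatter) is the first measured pair to isolate a change on this saturated chain carbon bound to a carbonyl carbon, and it shows that potency depends on the group held there. With all else unchanged, hydroxy, with its hydrogen-bond donor, gives way to dimethylamino, with three heavy atoms and no such donor, and the activity of compound 1 is not retained. Nothing measured here accounts for this loss, so its origin remains unknown.

A single pair cannot separate the effect of the nitrogen from that of its two methyl groups, and a primary amine at this carbon would bear on that question. As far as these compounds go, whether methoxy or a longer hydroxyalkyl chain would match or improve on hydroxy also remains open.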